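Hemolysis series: replacing the chloro group of compound 1

The source may hold more compounds than are shown below. What is called first, only, known or untested is meant among the compounds shown, and "the series" means these compounds.

Measured compounds:
compound 1 `N=C(N)c1ccc(-c2ccc(-c3ccc(Cl)cc3)o2)o1` — 70.7%
compound 2 `N=C(N)c1ccc(-c2ccc(-c3ccc(F)cc3)s2)s1` — 59.7%
compound 3 `COc1ccc(-c2ccc(-c3ccc(C(=N)N)s3)s2)cc1` — 63.7%

In an ADME assay on cells (Erythrocyte, Homo sapiens) for activation, read by hemolysis, with a stated time of 30 min, tested at 5 mM (a higher number here means a stronger effect of the compound at the concentration tested, a lower number a weaker effect), compound 1 gives 70.7%, the highest of the three numbers. Compound 3 stands nearest with 63.7%, a gap within the scatter, and compound 2 furthest with 59.7%, a gap beyond it. For the measured compounds named here, the only step measured between two compounds is a number 4 percentage points higher from compound 2 to compound 3 (within the scatter), a change that stays within the scatter.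

Compound 4 `N=C(N)c1ccc(-c2ccc(-c3ccccc3)o2)o1` differs from compound 1 by hydrogen in place of chloro on an aromatic carbon. Going by the values given here, no measured step exchanges a halogen for hydrogen, so the series gives no direct guide; the single measured step exchanged one substituent on the terminal ring for another and stayed within the scatter, which is weak evidence that such exchanges move the read-out little. The step of a number 6.7 percentage points lower from compound 1 to compound 4 (within the scatter) is therefore expected to stay within the scatter, if anything slightly downward. Compound 4 is estimated at 64%, with a range from 50% to 78%.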

Compound 4, a percentage reported as activity, at one concentration (the size of the read-out at that concentration, not a potency): 30.1%
Compound 4: the middle estimate sits 33.9 percentage points above what was measured; measured number outside the range, below it.
By their numbers in this assay, from the lowest: compound 4; then compounds 2, 3 and 1 (each within the scatter of the next, the first and the last beyond it).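

In this assay, for the compounds shown here, hydrogen in place of chloro on an aromatic carbon gives a number 40.6 percentage points lower from compound 1 to compound 4 (beyond the scatter) and is the first step to pass beyond the scatter. Going by these compounds alone, the only earlier step, a number 4 percentage points higher from compound 2 to compound 3 (within the scatter) on the same ring position, exchanged one substituent for another, whereas this one leaves the position para to a large group with no substituent, and the read-out proves sensitive to that change. Nothing available accounts for the size of the step.

As far as these compounds go, whether any substituent at this place would hold the read-out up, or chloro specifically, remains open: bromo, an amine or a carboxylic acid on the core of compound 1 would separate the two. Also open, from the compounds shown here alone, is whether hydrogen at this place has a similar effect on the core of compound 2.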